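The source may report more compounds than this note shows. Statements on the series, on what has been measured and on what is new or still open speak of the compounds shown alone.

The three compounds measured so far, with their numbers in a physicochemical assay for solubility, at pH 7.4; a lower number here means a less soluble compound, a higher number a more soluble compound:

compound 1, `O=C(CC(c1ccccc1)c1ccccc1)N1CCN(C(c2ccccc2)c2cccc(Cl)c2)CC1`, 0.37 ug/mL
compound 2, `O=C(CC(c1ccccc1)c1ccccc1)N1CCN(C(c2ccccc2)c2cccc(C(F)(F)F)c2)CC1`, 0.14 ug/mL
compound 3, `O=C(NC(c1ccccc1)c1ccccc1)N1CCN(C(c2ccccc2)c2ccccc2)CC1`, 0.38 ug/mL

Compound 2 stands at the bottom of this small set. Among the measured compounds shown here, its closest neighbour on the numbers is compound 1, and the one step between compounds differing in a single place is a 2.6-fold lower number from compound 1 to compound 2 (0.42 log units; beyond the scatter), a modest but real drop for the trifluoromethyl in place of chloro on an aromatic carbon. For the measured compounds named here, compound 3, with its different linker, gives a number in the same region as compound 1, and no single-point step connects it to compound 2.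

Compound 4, `CN1CCC(C(c2ccccc2)N2CCN(C(=O)CC(c3ccccc3)c3ccccc3)CC2)CC1`, has not yet been measured. It differs from compound 2 in one place: 1-methylpiperidin-4-yl in place of 3-(trifluoromethyl)phenyl on a saturated chain carbon bound to an amine nitrogen in a ring and an aromatic carbon. Going by the values given here, only the step from compound 1 to compound 2 bears on this at all, and only loosely, since it exchanges one substituent on an aromatic ring for another, whereas here a whole aromatic ring leaves and a six-membered non-aromatic ring carrying a hydrogen-bond acceptor enters. Among the compounds with values here, no measured pair shows a change of that kind, so the expectation rests on the structural change alone. Compound 4 is expected to give a higher number, and the estimate is 5 ug/mL, with a wide range from 0.5 ug/mL to 50 ug/mL. That amounts to an expected step of a 36-fold higher number from compound 2 to compound 4 (1.55 log units; beyond the scatter).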

Compound 4, solubility: 63.6 ug/mL
Compound 4: the middle estimate sits 13-fold (1.10 log units) below what was measured, and the stated range ends below it.
By their numbers in this assay, from the lowest: compound 2; then compounds 1 and 3 (each within the scatter of the next); then compound 4.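

In this assay the saturated chain carbon bound to an amine nitrogen in a ring and an aromatic carbon proves a far more sensitive place than the earlier substituent exchange could show: 1-methylpiperidin-4-yl in place of 3-(trifluoromethyl)phenyl gives a 450-fold higher number from compound 2 to compound 4 (2.66 log units; beyond the scatter) and so dwarfs the earlier 2.6-fold lower number from compound 1 to compound 2 (0.42 log units; beyond the scatter) on the aromatic ring. The same exchange made on 3-chlorophenyl gives a 170-fold higher number from compound 1 to compound 4 (2.24 log units; beyond the scatter) and is also large, so in these two pairs the rise does not depend on which of the two aryl groups leaves, although the step from compound 2 remains the larger of the two. Nothing measured here tells why the number rises so steeply at this place.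

The compounds shown do not separate the departure of the aromatic ring from the arrival of the ring nitrogen, and a cyclohexyl group at this place would carry the first change without the second. Also open, as far as these compounds go, is what the methyl on that nitrogen contributes, which a piperidin-4-yl group with a free ring amine would address, and whether a morpholine ring would serve in the same way.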